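Changing the aromatic group on the ring nitrogen in a toxicity series

The source may hold more compounds than are shown below. What is called first, only, known or untested is meant among the compounds shown, and "the series" means these compounds.

Compound 1, `Cc1cccc(N2CCN(CC(=O)N(c3ccccc3)c3ccccc3)CC2)c1C`, in a toxicity assay on the whole organism (strain albino) for activation, with Mus musculus as the target, with stated times of 30 min and 240 min (a higher number here means that more compound is needed for the effect, a lower number that less compound is needed), gives a limit of > 40 mg/kg.
Compound 2, `COc1cccc(N2CCN(CC(=O)N(c3ccccc3)c3ccccc3)CC2)c1`, in this assay gives 55.4 mg/kg.

Among the measured compounds shown here, compound 2 holds the only number measured so far in this assay; the other value is a limit, (the limit of > 40 mg/kg in this assay, at which 1 of the 2 values shown sits). For the measured compounds named here, the single measured step, a step that the limit leaves unreadable from compound 1 to compound 2, cannot be read in size because compound 1 sits at that limit. Compound 3, `O=C(CN1CCN(c2ccc(Cl)c(Cl)c2)CC1)N(c1ccccc1)c1ccccc1`, differs from compound 2 by 3,4-dichlorophenyl in place of 3-methoxyphenyl on an amine nitrogen in a ring. Going by the values given here, no measured step therefore speaks to this change, and the only guide is the number for compound 2 itself. With nothing pointing either way, no step beyond the scatter is expected in this assay, but the range must stay wide. Compound 3 is estimated at 50 mg/kg, between 20 mg/kg and 120 mg/kg, an expected step of a 1.1-fold lower number from compound 2 to compound 3 (0.04 log units; within the scatter) that means no change beyond the scatter.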

Compound 3, dose for half-maximal effect: 45 mg/kg
Compound 3: the middle estimate sits 1.1-fold (0.05 log units) above what was measured, within the range that was stated.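

Among the compounds shown here, this gives the first readable step at this position, the amine nitrogen in a ring: in this assay, the change to 3,4-dichlorophenyl gives a 1.2-fold lower number from compound 2 to compound 3 (0.09 log units; within the scatter). Replacing the 3-methoxyphenyl, with its one hydrogen-bond acceptor, by a ring with two chlorine atoms and no acceptor therefore goes with no change beyond the scatter. The steps from compound 1 cannot be read, as its value is only a limit: the limit of > 40 mg/kg in this assay, at which 1 of the 3 values shown sits.

For the compounds shown here, still open is whether any group on this nitrogen can move the number beyond the scatter, since the two readable values cover only two substituted phenyl rings. A phenyl ring carrying a carboxylic acid or an amine, or a plain alkyl chain in place of the aromatic ring, would probe this position more widely.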